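Replacing the Sulfamoylphenyl Group on a Nucleoside Triazole

The source may report more compounds than this note shows. Statements on the series, on what has been measured and on what is new or still open speak of the compounds shown alone.

Compound 1 `Cc1cn([C@H]2C[C@@H](n3cc(COc4ccc(S(N)(=O)=O)cc4)nn3)[C@@H](CO)O2)c(=O)[nH]c1=O` was tested in an assay on isolated protein for inhibition of carbonic anhydrase 5B, mitochondrial (Homo sapiens), read by stopped-flow (a lower number here means a stronger inhibitor, a higher number a weaker inhibitor), where compound 1 gives 141 nM. Within the data shown here, of the two numbers measured so far, this is the highest; the only other compound, compound 2 `Cc1cn([C@H]2C[C@@H](n3cc(COC(=O)c4ccc(S(N)(=O)=O)cc4)nn3)[C@@H](CO)O2)c(=O)[nH]c1=O`, gives in this assay a value of 54.2 nM, a lower number by a margin beyond the usual scatter. Compound 3 `Cc1cn([C@H]2C[C@@H](n3cc(COc4ccc5oc(=O)ccc5c4)nn3)[C@@H](CO)O2)c(=O)[nH]c1=O` has not yet been measured. It differs from compound 1 in one place: a group of 11 heavy atoms (9 carbon, 2 oxygen; one six-membered aromatic ring of carbon only, one six-membered aromatic ring with 1 hetero atom) in place of a group of 10 heavy atoms (6 carbon, 1 nitrogen, 2 oxygen, 1 sulfur; one six-membered aromatic ring of carbon only), on an oxygen on a saturated carbon. Among the measured compounds shown here, both compounds measured so far carry the 4-sulfamoylphenyl group that leaves here, so no measured step shows what happens when it is taken away. In this assay a markedly weaker result is expected for compound 3, with the step of a 14-fold higher number from compound 1 to compound 3 (1.15 log units; beyond the scatter) estimated to be large and toward higher numbers. Compound 3 is accordingly expected to give about 2000 nM, within a range from 400 nM to 9000 nM.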

Compound 3, inhibition constant: 161 nM
Compound 3: middle estimate off by 12-fold (1.09 log units), on the high side; the whole stated range lies above it.
By their numbers in this assay, from the lowest: compound 2; then compounds 1 and 3 (each within the scatter of the next).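

In this assay, the step at this position is a 1.1-fold higher number from compound 1 to compound 3 (0.06 log units; within the scatter), with the 4-sulfamoylphenyl group on the oxygen on a saturated carbon replaced by a group of 11 heavy atoms that holds neither nitrogen nor sulfur. Among these compounds, both earlier compounds carry the 4-sulfamoylphenyl group, so this is the first sign that, on this core, a number of this size does not depend on that group. Nothing measured here accounts for this result.

From the compounds shown here alone, what a plain phenyl group or a 4-carboxyphenyl group would give on the same oxygen stays open, so the loss of the sulfamoyl group cannot yet be separated from the gain of the second ring. Also open, going by these compounds, is how the entering group would behave on the ester link that compound 2 carries.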